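Replacing 4-chloro-3-(trifluoromethyl)phenyl in compound 2

A few compounds are considered here, and "the series" means these few. Any claim that something is new, unique, unknown or untested is made for them only; others in the source may bear on it.

In an ADME assay on HEK293 cells (Homo sapiens) for cytotoxicity, read by resazurin assay, with a stated time of 48 h (on this read-out lower numbers stand for higher toxicity in this test and higher numbers for lower toxicity in this test), compound 2 (`O=S(=O)(Nc1ccc(-c2nc3cc(NS(=O)(=O)c4ccc(Cl)s4)ccc3o2)cc1)c1ccc(Cl)c(C(F)(F)F)c1`) gives 34000 nM as the second highest of three numbers. This lies within the scatter of compound 1 (`COc1ccc(S(=O)(=O)Nc2ccc(-c3nc4cc(NS(=O)(=O)c5ccc(OC)cc5)ccc4o3)cc2)cc1`) at 48000 nM in the same test. Compound 3 (`COc1ccc(S(=O)(=O)Nc2ccc3oc(-c4ccc(NC(=O)c5ccc(Cl)s5)cc4)nc3c2)cc1`) holds the lowest number at 15000 nM in this set.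

Compound 4 (`O=S(=O)(Nc1ccc(-c2nc3cc(NS(=O)(=O)c4ccc(Cl)s4)ccc3o2)cc1)c1ccc(Cl)s1`) has 5-chlorothiophen-2-yl in place of 4-chloro-3-(trifluoromethyl)phenyl on a sulfonyl sulfur. For the measured compounds named here, only one measured step bears on this change, and only in part. That step is a 3.2-fold lower number from compound 1 to compound 3 (0.51 log units; beyond the scatter) and it is modest. It brought in (5-chlorothiophen-2-yl)carbonyl in place of (4-methoxyphenyl)sulfonyl, so the group that left differs and the sulfonyl was lost as well. A small move towards a lower number in this assay is therefore expected, quite possibly none beyond the scatter. The expected change is a 1.3-fold lower number from compound 2 to compound 4 (0.12 log units; within the scatter) and remains an estimate. Compound 4 is estimated at 26000 nM with 12000 nM as the lower end and 55000 nM as the upper end of the expected range.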

Compound 4, half-maximal cytotoxic concentration: 41000 nM
The estimate for compound 4 lay 1.6-fold (0.20 log units) below the measured number, within the range that was stated.
By their numbers in this assay, from the lowest: compound 3; then compounds 2, 4 and 1 (each within the scatter of the next).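

Swapping 4-chloro-3-(trifluoromethyl)phenyl for 5-chlorothiophen-2-yl on a sulfonyl sulfur gives a 1.2-fold higher number from compound 2 to compound 4 (0.08 log units; within the scatter) in this assay. Here the sulfonyl stays in place, so only the group on it changes, whereas compound 3 carries a carbonyl at the corresponding nitrogen; going from a six-membered aromatic ring of carbon only to a five-membered aromatic ring with 1 hetero atom leaves the number within the scatter. No supporting measurement accounts for this result.

From the compounds shown here alone, whether this sulfonyl sulfur tolerates a non-aromatic group, such as an aminoethyl chain or a carboxylic acid-bearing chain, remains open. Also open, going by these compounds, is whether the same swap holds when the other sulfonamide on the shared core carries a different group.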